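Swapping Methoxy for Chloro on a Second Core

The compounds below may be only part of what the source reports. "The series", "measured", "known", "first", "only" and "open" are said of these compounds alone.

Compound 1 `COc1ccccc1N1CCN(CCCn2ncc(N3CCN(C(=O)c4ccco4)CC3)c(Cl)c2=O)CC1` and compound 2 `O=C(c1ccco1)N1CCN(c2cnn(CCCN3CCN(c4ccccc4Cl)CC3)c(=O)c2Cl)CC1` share one core and differ only in that (chloro in place of methoxy on an aromatic carbon). In an assay on cell membranes for binding affinity to Adrenergic receptor alpha-1 (Rattus norvegicus), read by radioligand binding (on this read-out higher numbers stand for weaker inhibition and lower numbers for stronger inhibition), compound 1 gives 20.4 nM, while compound 2 gives 3.5 nM, a step recorded as a 5.8-fold lower number from compound 1 to compound 2 (0.77 log units; beyond the scatter). Compound 3 `COc1ccccc1N1CCN(CCCCCn2nc(N3CCN(C(=O)c4ccco4)CC3)ccc2=O)CC1` is built on another core; the difference between the two cores is not broken down here. In this assay compound 3 gives 43.7 nM. Compound 4 `O=C(c1ccco1)N1CCN(c2ccc(=O)n(CCCCCN3CCN(c4ccccc4Cl)CC3)n2)CC1` is not yet measured; it differs from compound 3 in that (chloro in place of methoxy on an aromatic carbon), the same change at the same place as between compound 1 and compound 2. Because that change gave a 5.8-fold lower number from compound 1 to compound 2 (0.77 log units; beyond the scatter), a step in the same direction is expected here, namely a 4.9-fold lower number from compound 3 to compound 4 (0.69 log units; beyond the scatter). For compound 4 the estimated value in this assay is 9 nM, expected to fall between 3 nM and 30 nM.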

Compound 4, inhibition constant: 13.3 nM
Compound 4: the middle estimate sits 1.5-fold (0.17 log units) below what was measured; the measured number falls inside the stated range.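

Putting chloro in place of methoxy on the core of compound 3 again gives a lower number in this assay, namely a 3.3-fold lower number from compound 3 to compound 4 (0.52 log units; beyond the scatter). Set beside the earlier step on the other core, the two sizes cannot be told apart: the same change on two cores in this assay, a 5.8-fold lower number (0.77 log units; beyond the scatter) from compound 1 to compound 2 and a 3.3-fold lower number (0.52 log units; beyond the scatter) from compound 3 to compound 4, 1.8-fold (0.25 log units) apart, within the scatter of two such steps. On these two cores, then, the change carries over in direction and in similar size, but two cores are a small sample, so this does not show that it would hold on every core in the series, nor why the number falls.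

The compounds shown leave open how another group at the same place, such as fluoro, methyl or a nitrile, would compare with chloro. Among the compounds shown here, they also leave open whether the step would persist with a longer chain than the one in compound 4.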